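This account rests on a few compounds, and the source may have more. Where it says the series, first, only, none or still open, it means among the compounds named here.

Compound 2 `CN1C[C@H](C(=O)Nc2ccc(F)c(Cl)c2)[C@@H](c2ccc(/C=C/C(=O)Nc3ccccc3N)cc2)C1` and compound 1 `Cc1ccc(NC(=O)[C@H]2CN(C)C[C@@H]2c2ccc(/C=C/C(=O)Nc3ccccc3N)cc2)cc1` share one core and differ only in the aryl group on the amide-type nitrogen. In an in vitro ADME assay on microsomes from liver (Mus musculus) for pharmacokinetics, read by LC-MS, with a stated time of 10 min, tested at 1 uM (a higher number here means faster removal of the compound, a lower number slower removal), compound 1 gives 62 mL/min/kg, and compound 2 gives 34 mL/min/kg; the two values lie within the scatter of each other, as the step of a 1.8-fold lower number from compound 1 to compound 2 (0.26 log units; within the scatter) shows. Compound 3 `CN1C[C@H](C(=O)Nc2ccccn2)[C@@H](c2ccc(/C=C/C(=O)Nc3ccccc3N)cc2)C1` is the next member of the set. Its difference from compound 2 is pyridin-2-yl in place of 3-chloro-4-fluorophenyl on an amide-type nitrogen. Within the data shown here, the only measured step that bears on this change is the one from compound 1 to compound 2, an exchange of aryl groups at the same amide-type nitrogen, which stayed within the scatter. On that basis no step beyond the scatter is expected in this assay, and the estimated step is no change at the digits printed from compound 2 to compound 3 (within the scatter). Compound 3 is therefore expected to give about 34 mL/min/kg, with a likely range from 15 mL/min/kg to 75 mL/min/kg.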

Compound 3, clearance: 40 mL/min/kg
For compound 3 the middle estimate is 1.2-fold (0.07 log units) below the measured one, and the stated range covers the measured number.
By their numbers in this assay, from the lowest: compounds 2, 3 and 1 (each within the scatter of the next).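

In this assay, a ring with a hetero atom now stands on the amide-type nitrogen: pyridin-2-yl in place of 3-chloro-4-fluorophenyl gives a 1.2-fold higher number from compound 2 to compound 3 (0.07 log units; within the scatter), and pyridin-2-yl in place of 4-methylphenyl gives a 1.6-fold lower number from compound 1 to compound 3 (0.19 log units; within the scatter). All three aryl groups at this position thus lie within the scatter of one another, whether the six-membered aromatic ring carries methyl, carries chlorine and fluorine, or holds a ring nitrogen. No supporting measurement is available to account for this outcome.

From the compounds shown here alone, all three compounds carry a six-membered aromatic ring at this nitrogen, so it remains open whether cyclohexyl, a longer chain such as benzyl, or an aryl group bearing an amine or a carboxylic acid would also stay within the scatter. Going by these compounds, the rest of the structure is the same in all three, so the effect of a change elsewhere on this assay is also open.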